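The source may hold more compounds than are shown below. What is called first, only, known or untested is meant among the compounds shown, and "the series" means these compounds.

Compound 1 `O=S(=O)(NCCCNCC1COc2ccccc2O1)c1cc(C(F)(F)F)cc(C(F)(F)F)c1`: 1200 nM
Compound 2 `O=S(=O)(NCCCNCc1ccc(C(F)(F)F)cc1)c1cc(C(F)(F)F)cc(C(F)(F)F)c1`: 1700 nM

Within the data shown here, only two compounds have been measured in a functional assay on BXPC-3 cells (Homo sapiens) for inhibition, read by MTT assay, with a stated time of 72 h (a lower number here means a stronger inhibitor of growth, a higher number a weaker inhibitor of growth), and compound 2 gives 1700 nM there. Among the measured compounds shown here, the single measured step, a 1.4-fold higher number from compound 1 to compound 2 (0.15 log units; within the scatter), lies within the scatter, so the two measured compounds cannot be told apart on these numbers. Compound 3 `O=S(=O)(NCCCNCc1cccc(Cl)c1)c1cc(C(F)(F)F)cc(C(F)(F)F)c1` carries one change against compound 2: 3-chlorophenyl in place of 4-(trifluoromethyl)phenyl on a saturated chain carbon bound to an amine nitrogen. For the measured compounds named here, the one step that bears on this change is the step from compound 1 to compound 2, which swapped the group at the same saturated chain carbon and moved the number by a 1.4-fold higher number from compound 1 to compound 2 (0.15 log units; within the scatter) only. With this small precedent, little movement is expected in this assay for compound 3, and its step is estimated as a 1.1-fold lower number from compound 2 to compound 3 (0.05 log units; within the scatter). Compound 3 is therefore expected to give about 1500 nM, within a range of 600 nM to 4000 nM.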

Compound 3, concentration for 50% growth inhibition: 3800 nM
Compound 3: middle estimate off by 2.5-fold (0.40 log units), on the low side; measured number inside the range.
By their numbers in this assay, from the lowest: compounds 1 and 2 (each within the scatter of the next); then compound 3.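

In this assay, among these compounds, the group on a saturated chain carbon bound to an amine nitrogen now shows a real effect: 3-chlorophenyl in place of 4-(trifluoromethyl)phenyl gives a 2.2-fold higher number from compound 2 to compound 3 (0.35 log units; beyond the scatter), the first step at this position beyond the scatter. Set against the 2,3-dihydro-1,4-benzodioxin-2-yl group, the same 3-chlorophenyl gives a 3.2-fold higher number from compound 1 to compound 3 (0.50 log units; beyond the scatter), so this position tolerates some groups better than others, although both steps are modest. Nothing available explains why growth inhibition weakens with this group.

The change replaces both the substituent and its ring position at once, so the compounds shown cannot separate those two contributions. A 4-chlorophenyl or a 3-(trifluoromethyl)phenyl group would be the direct test, and an unsubstituted phenyl group would show what either substituent adds.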